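Dichloro versus monochloro purines on lung cancer cells

The source may report more compounds than this note shows. Statements on the series, on what has been measured and on what is new or still open speak of the compounds shown alone.

Compound 1 `ClCc1ccc(Cn2cnc3nc(Cl)nc(Cl)c32)cc1` and compound 3 `ClCc1ccccc1Cn1cnc2nc(Cl)nc(Cl)c21` were tested in a functional assay on HOP-62 cells (Homo sapiens) for cytotoxicity, read by sulforhodamine B assay, with a stated time of 48 h; on this read-out lower numbers stand for stronger inhibition of growth and higher numbers for weaker inhibition of growth; compound 1 gives 1900 nM and compound 3 gives 2690 nM, the two values within scatter of each other. The difference between these two cores is not broken down here. Compound 2 `ClCc1ccccc1Cn1cnc2ncnc(Cl)c21` gives 11200 nM, and the change hydrogen in place of chloro on an aromatic carbon brought a 4.2-fold higher number from compound 3 to compound 2 (0.62 log units; beyond the scatter). Compound 4 `ClCc1ccc(Cn2cnc3ncnc(Cl)c32)cc1` has not yet been measured in this assay. It arises from compound 1 by hydrogen in place of chloro on an aromatic carbon, the same change as that from compound 3 to compound 2. Because the measured step was a 4.2-fold higher number from compound 3 to compound 2 (0.62 log units; beyond the scatter), a step of similar size, a 4.2-fold higher number from compound 1 to compound 4 (0.62 log units; beyond the scatter), is expected here, resting on that single precedent and on the value of compound 1, 1900 nM. Compound 4 is thus estimated at 8000 nM, plausibly between 3500 nM and 18000 nM.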

Compound 4, concentration for 50% growth inhibition: 1770 nM
Compound 4: middle estimate off by 4.5-fold (0.66 log units), on the high side, outside the stated range (below it).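

In this assay, hydrogen in place of chloro on an aromatic carbon between two ring nitrogen atoms brought a 1.1-fold lower number from compound 1 to compound 4 (0.03 log units; within the scatter). The same change thus differs in size between the two cores: the same change on two cores in this assay, a 4.2-fold higher number (0.62 log units; beyond the scatter) from compound 3 to compound 2 and a 1.1-fold lower number (0.03 log units; within the scatter) from compound 1 to compound 4, 4.5-fold (0.65 log units) apart, beyond the scatter of two such steps. The step seen on the core of compound 3 therefore cannot simply be carried over to the core of compound 1, but two pairs do not show why the steps part or how the change would behave on any further core.

The compounds shown leave open how an amine or a methoxy group in place of chloro on that carbon would read on either core. They also leave open what a hydroxymethyl group in place of the chloromethyl group would do.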